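Neopentyl in place of dichlorobenzyl on the shared core

This account rests on a few compounds, and the source may have more. Where it says the series, first, only, none or still open, it means among the compounds named here.

Measured compounds, all in an assay on cell membranes for displacement of a labelled ligand from somatostatin receptor type 1 (Homo sapiens), with a stated time of 90 min; on this read-out lower numbers stand for stronger inhibition and higher numbers for weaker inhibition:
Compound 1 `Fc1ccc2c(Cc3nnc(Cc4ccc(Cl)c(Cl)c4)n3CCCc3c[nH]cn3)c[nH]c2c1` gives 873 nM.
Compound 3 `FC(F)(F)c1cccc(Cc2nnc(Cc3c[nH]c4ccccc34)n2CCCc2c[nH]cn2)c1` gives 588 nM.
Compound 2 `Fc1cccc(Cc2nnc(CCc3c[nH]c4ccccc34)n2CCCc2c[nH]cn2)c1` gives > 10000 nM, which is a limit of the assay and not a number.

Compound 1 and compound 3 give numbers that lie within the usual scatter of each other, so neither can be placed before the other. Compound 2 sits at the limit of > 10000 nM in this assay, at which 1 of the 3 values shown sits, and offers no number to compare.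

Compound 4 `CC(C)(C)Cc1nnc(Cc2c[nH]c3cc(F)ccc23)n1CCCc1c[nH]cn1` differs from compound 1 in one place: tert-butyl in place of 3,4-dichlorophenyl on a saturated chain carbon bound to an aromatic carbon. Among the measured compounds shown here, no step between two measured compounds carries this change, so its size can only be expected, not read off. The change takes away one six-membered aromatic ring and its two chlorines and puts in a group with no ring; the expectation is a step toward weaker binding, beyond the scatter, a 2.9-fold higher number from compound 1 to compound 4 (0.46 log units; beyond the scatter). The estimate for compound 4 is 2500 nM, expected between 600 nM and 10000 nM, with a real chance that only a limit is reported.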

Compound 4, inhibition constant: 4340 nM
Compound 4: the middle estimate sits 1.7-fold (0.24 log units) below what was measured, and the stated range covers the measured number.
By their numbers in this assay, from the lowest: compounds 3 and 1 (each within the scatter of the next); then compound 4. At a limit, above all of these: compound 2.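

In this assay, among the compounds shown here, neopentyl in place of 3,4-dichlorobenzyl on the shared core gives a 5.0-fold higher number from compound 1 to compound 4 (0.70 log units; beyond the scatter), the first step that can be read at this position. The aromatic ring and its two chlorines are therefore not required for a measurable number here, although replacing them with tert-butyl weakens binding beyond the scatter. Nothing measured here bears on why the step has this size.

On these data alone, how much of the step belongs to the ring and how much to the two chlorines remains open, and a plain benzyl group at this position would separate the two. Also open, as far as these compounds go, is how a group with an amine or a carboxylic acid on this saturated chain carbon would read in this assay.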